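The compounds below may be only part of what the source reports. "The series", "measured", "known", "first", "only" and "open" are said of these compounds alone.

Of the compounds shown here, three sharing one core have been tested in a functional assay on A-431 cells (Homo sapiens) for antiproliferative activity, read by MTT assay, with a stated time of 72 h; a lower number here means a stronger inhibitor, a higher number a weaker inhibitor. Compound 3 `COc1cc2ncnc(Nc3ccc(Cl)cc3)c2cc1OCCCCC(=O)Nc1ccc(S(N)(=O)=O)cc1` gives 7120 nM there, the lowest number of the three. Compound 1 `C#Cc1cccc(Nc2ncnc3cc(OC)c(OCCCCC(=O)Nc4ccc(S(N)(=O)=O)cc4)cc23)c1` gives 17700 nM in this assay, and compound 2 `COc1cc2ncnc(Nc3cccc(F)c3)c2cc1OCCCCC(=O)Nc1ccc(S(N)(=O)=O)cc1` gives 29900 nM. The step of a 2.5-fold lower number from compound 1 to compound 3 (0.40 log units; beyond the scatter) and the step of a 4.2-fold lower number from compound 2 to compound 3 (0.62 log units; beyond the scatter) both show that exchanging the group on a nitrogen on an aromatic ring shifts the number modestly, while the step of a 1.7-fold higher number from compound 1 to compound 2 (0.23 log units; within the scatter) lies within the scatter.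

Compound 4 `COc1cc2ncnc(Nc3ccc(OC(F)(F)F)cc3)c2cc1OCCCCC(=O)Nc1ccc(S(N)(=O)=O)cc1` has not yet been measured. It differs from compound 3 in one place: trifluoromethoxy in place of chloro on an aromatic carbon. Within the data shown here, no measured step replaces exactly this group, so the two steps leading to compound 3 are the nearest guides. They show that changes on this ring move this assay by modest amounts, and that the two rings giving higher numbers than compound 3 differ from each other only within the scatter. For compound 4 a shift of similar modest size, or none beyond the scatter, is expected, with the direction uncertain. Compound 4 is therefore estimated at 9000 nM, within a range from 3500 nM to 25000 nM. In step terms this estimate means an expected 1.3-fold higher number from compound 3 to compound 4 (0.10 log units; within the scatter).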

Compound 4, half-maximal inhibitory concentration: 22500 nM
Estimate against measurement, compound 4: 2.5-fold (0.40 log units) below, and the stated range covers the measured number.
By their numbers in this assay, from the lowest: compound 3; then compounds 1, 4 and 2 (each within the scatter of the next).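

In this assay, trifluoromethoxy in place of chloro on the aromatic carbon para to a large group gives a 3.2-fold higher number from compound 3 to compound 4 (0.50 log units; beyond the scatter), so exchanging the group at this one position, with the rest of the molecule held constant, moves the number modestly. The lower number of compound 3 is therefore tied to chloro among the two groups tested here, not simply to having a group at this position, and compound 4 sits level with the other two compounds, as a 1.3-fold lower number from compound 2 to compound 4 (0.12 log units; within the scatter) and a 1.3-fold higher number from compound 1 to compound 4 (0.10 log units; within the scatter) show, leaving only compound 3 apart from the rest. No measurement available here accounts for the difference between chloro and trifluoromethoxy.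

From the compounds shown here alone, two groups at this position cannot establish a trend, so it remains open how bromo, methyl or a plain hydrogen there would compare with chloro. Going by these compounds, it is also open whether chloro would keep its lower number with a shorter or longer chain between the core and the amide.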